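The compounds below may be only part of what the source reports. "The series", "measured", "known", "first", "only" and "open" are said of these compounds alone.

Compound 1 `O=C(O)CCCCCCC(=O)Nc1ccc(C2=C(c3ccc(O)cc3)C3CC(S(=O)(=O)Oc4cccc5ccccc45)C2O3)cc1` is the starting point of this account. In an assay on isolated protein for inhibition of protein deacetylase HDAC6 (Homo sapiens), read by fluorescence, with a stated time of 15 min (on this read-out lower numbers stand for stronger inhibition and higher numbers for weaker inhibition), compound 1 is reported as "not active" (no number reported), so no single number describes where it stands, only that it showed no measurable inhibition. Two further compounds from the same series give numbers. Compound 2 `O=C(CCCCCCC(=O)Nc1ccc(C2=C(c3ccc(O)cc3)C3CC(S(=O)(=O)Oc4cccc5ccccc45)C2O3)cc1)NO` gives 30 nM in this assay. Compound 3 `O=C(O)CCCCCCC(=O)Nc1ccc(OS(=O)(=O)C2CC3OC2C(c2ccc(O)cc2)=C3c2ccc(O)cc2)cc1` gives 8340 nM in this assay. Going by the values given here, no step between any two of these measured compounds can be drawn from a single structural difference, so the account says only what each value shows on its own.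

The compound to be judged is compound 4 `O=C(O)CCCCCCC(=O)Nc1ccc(C2=C(c3ccc(O)cc3)C3CC(S(=O)(=O)Oc4ccc5ccccc5c4)C2O3)cc1`. It differs from compound 1 in one place: naphthalen-2-yl in place of naphthalen-1-yl on an oxygen whose other neighbour is a sulfonyl sulfur. Among the compounds with values here, since compound 1 has no number, no step in this assay can be sized for this change, and nothing among the measured compounds speaks to it.

Compound 4 is expected to behave much as compound 1 does and to be weak, with an estimated value of 20000 nM and a range from 4000 nM to 100000 nM, with a real chance that only a limit is reported.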

Compound 4, half-maximal inhibitory concentration: 8110 nM
Compound 4: middle estimate off by 2.5-fold (0.39 log units), on the high side, within the range that was stated.
By their numbers in this assay, from the lowest: compound 2; then compounds 4 and 3 (each within the scatter of the next).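

Going by these compounds alone, compound 1 has no number, so compound 4 at 8110 nM gives no step from it and none can be read. Nothing shown offers a measured explanation for this value. The compounds shown leave open whether naphthalen-2-yl in place of naphthalen-1-yl on an oxygen changes inhibition at all.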